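The compounds below may be only part of what the source reports. "The series", "measured", "known", "first", "only" and "open" are said of these compounds alone.

Measured in a functional assay on NCI-H460 cells (Homo sapiens) for inhibition, read by MTT assay, with a stated time of 24 h, tested at 1 ug/mL; on this read-out lower numbers stand for less inhibition of growth and higher numbers for more inhibition of growth at the one concentration tested:
compound 1 `O=C(CCCCC(S)CCS)Nc1ccccc1` — 4.3%
compound 2 `O=C(CCCCC(S)CCS)Nc1ccccc1Cl` — 8.19%
compound 3 `CC(=O)SCCC(CCCCC(=O)Nc1ccccc1)SC(C)=O` — 13.1%

The three values lie close to one another. Compound 2 differs from compound 1 by chloro in place of hydrogen on an aromatic carbon, and this change gave a number 3.9 percentage points higher from compound 1 to compound 2 (within the scatter). Compound 3 rests on a different core; the difference between the core of compound 3 and the core of compound 1 is not broken down here. Compound 4 `CC(=O)SCCC(CCCCC(=O)Nc1ccccc1Cl)SC(C)=O` has not yet been measured in this assay. It differs from compound 3 by chloro in place of hydrogen on an aromatic carbon, which is the same change as that from compound 1 to compound 2, at the same kind of place. Among the compounds with values here, the step from compound 3 to compound 4 is expected to be a number 2.9 percentage points higher from compound 3 to compound 4 (within the scatter), an expectation that rests on the one measured instance of this change, which gave a number 3.9 percentage points higher from compound 1 to compound 2 (within the scatter). Compound 4 is therefore expected to give about 16% in this assay. The estimated range for compound 4 runs from 6% to 28%.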

Compound 4, percent growth inhibition at one concentration: 13.2%
Compound 4: middle estimate off by 2.8 percentage points, on the high side, and the stated range covers the measured number.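

In this assay, chloro in place of hydrogen on an aromatic carbon gave a number 0.1 percentage points higher from compound 3 to compound 4 (within the scatter), and set beside the earlier step this reads: the same change on two cores in this assay, a number 3.9 percentage points higher (within the scatter) from compound 1 to compound 2 and a number 0.1 percentage points higher (within the scatter) from compound 3 to compound 4, 3.8 percentage points apart, within the scatter of two such steps

On these two pairs, the cores give no sign of handling the change differently, so the step on the core of compound 1 is a fair guide to the step on the core of compound 3. Both steps lie within the scatter, however, so neither pair shows that chloro changes growth inhibition on either core, and two pairs at one concentration set no general rule.

The compounds shown leave open whether a different group at this place, such as methoxy or an amine, would give a step beyond the scatter. As far as these compounds go, a longer chain in the amide part also remains open on both cores.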